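Methyl for chloro on the anilide of compound 1

The source may report more compounds than this note shows. Statements on the series, on what has been measured and on what is new or still open speak of the compounds shown alone.

Compound 1 `COc1ccc2c(=O)c(/C=C/C(=O)Nc3ccccc3Cl)coc2c1` is the reference point for the step considered here. In a functional assay (QGY7701 cells, Homo sapiens) for inhibition, read by MTT assay, with a stated time of 48 h (on this read-out higher numbers stand for weaker inhibition and lower numbers for stronger inhibition), compound 1 gives 23000 nM, the lowest of the two numbers measured in this set. Compound 2 `COc1ccc2c(=O)c(/C=C/C(=O)NCc3ccccc3F)coc2c1` gives 34000 nM in this assay, and the step of a 1.5-fold higher number from compound 1 to compound 2 (0.17 log units; within the scatter) is 2-fluorobenzyl in place of 2-chlorophenyl on an amide-type nitrogen. Compound 3 `O=C(/C=C/c1coc2cc(O)ccc2c1=O)NCc1ccc(F)cc1` returns only a limit in this assay, > 100000 nM, so no number is known for it. One of the three values shown sits at the limit of > 100000 nM in this assay, at which 1 of the 3 values shown sits.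

Compound 4 `COc1ccc2c(=O)c(/C=C/C(=O)Nc3ccccc3C)coc2c1` differs from compound 1 by methyl in place of chloro on an aromatic carbon. Among the measured compounds shown here, no measured step in this set changes this group alone, and the only measured step that touches the same amide-type nitrogen, a 1.5-fold higher number from compound 1 to compound 2 (0.17 log units; within the scatter), concerns a different replacement and stays within the scatter. There is thus no measured evidence of a shift in either direction for such a small exchange on this ring, and the step of a 1.1-fold higher number from compound 1 to compound 4 (0.04 log units; within the scatter) is expected to stay within the scatter, with no preferred direction. Compound 4 is therefore estimated at 25000 nM in this assay, with a range from 10000 nM to 70000 nM.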

Compound 4, half-maximal inhibitory concentration: 22500 nM
For compound 4 the middle estimate is 1.1-fold (0.05 log units) above the measured one; the measured number falls inside the stated range.
By their numbers in this assay, from the lowest: compounds 4, 1 and 2 (each within the scatter of the next). At a limit, above all of these: compound 3.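

In this assay, the aromatic carbon ortho to a large group now has a direct reading: a 1.0-fold lower number from compound 1 to compound 4 (0.01 log units; within the scatter) for methyl in place of chloro, so the two compounds cannot be told apart and chloro is not needed at this carbon for a value of this size. The comparison across the amide-type nitrogen gives a 1.5-fold lower number from compound 2 to compound 4 (0.18 log units; within the scatter) for 2-methylphenyl in place of 2-fluorobenzyl, so this larger exchange also yields no separation, and the three compounds with numbers stay within the scatter of one another. Nothing in the data shown accounts for this flat reading.

Among the compounds shown here, still open is whether a group of another kind on this carbon, such as an amine, a carboxylic acid or a longer chain, would move the number beyond the scatter, since chloro and methyl are the only two groups read here. Compound 3 gives only a limit, > 100000 nM, and it differs from compound 2 in more than one place, so it cannot show which single change on the shared scaffold would separate a compound from this group.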